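A few compounds are considered here, and "the series" means these few. Any claim that something is new, unique, unknown or untested is made for them only; others in the source may bear on it.

The measured compounds:
Compound 1 `Cc1ccccc1Nc1nc(C)c(C(=O)/C=C/c2ccccc2)s1` gives in a functional assay on NCI-H460 cells (Homo sapiens) for cytotoxicity, read by MTT assay (a lower number here means a stronger inhibitor, a higher number a weaker inhibitor), only a limit of the assay, > 25000 nM.
Compound 2 `Cc1cccc(Nc2nc(C)c(C(=O)/C=C/c3ccccc3)s2)c1` gives in this assay 21800 nM.
Compound 3 `Cc1nc(Nc2ccccc2)sc1C(=O)/C=C/c1ccccc1` gives in this assay only a limit of the assay, > 25000 nM.

Compound 3 therefore stands at a limit, not at a number, and it shares that position with one other value (the limit of > 25000 nM in this assay, at which 2 of the 3 values shown sit). Compound 4 `Cc1ccc(Nc2nc(C)c(C(=O)/C=C/c3ccccc3)s2)cc1` differs from compound 3 in one place: methyl in place of hydrogen on an aromatic carbon. The measured steps that bear on this change all concern a methyl on the same six-membered ring. The step of an at least 1.1-fold higher number from compound 2 to compound 3 (0.05 log units; that floor lies within the scatter) removes a methyl and gives a higher number whose floor lies within the scatter; the step that the two limits leave unreadable from compound 1 to compound 3 cannot be sized from two limits; the step of an at least 1.1-fold lower number from compound 1 to compound 2 (0.05 log units; that floor lies within the scatter) moves a methyl with no change beyond the scatter. Adding a methyl in the new place is thus expected to change the number little, if at all, beyond the scatter. For compound 4 the step is estimated as a number no higher from compound 3 to compound 4 (the limit leaves the size open). Compound 4 is accordingly expected at 25000 nM, within a range from 8000 nM to 70000 nM, with a real chance that the assay again reports only a limit.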

Compound 4, half-maximal inhibitory concentration: > 25000 nM
Compound 4: a limit, no number; the forecaster's own chance of this, stated with the estimate: 55%; the middle value lies on the limit itself.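

In this assay, 4-methylphenyl in place of 3-methylphenyl gives an at least 1.1-fold higher number from compound 2 to compound 4 (0.05 log units; that floor lies within the scatter), so the part of this step that can be read does not go beyond the scatter. The steps to compound 4 from compound 3 and from compound 1 join two limits and cannot be read, which means that adding the methyl to the plain phenyl ring has no measurable size here. Compound 4 is a third case at the limit, and compound 2 remains the only compound shown with an actual number: the limit of > 25000 nM in this assay, at which 3 of the 4 values shown sit.

Going by these compounds, how far compound 1, compound 3 and compound 4 lie past that limit stays open. Also open, on these data alone, is what an amine, a carboxylic acid or a longer chain would do in place of the methyl at this position.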